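Dropping the methoxy from a nucleotide analogue

A few compounds are considered here, and "the series" means these few. Any claim that something is new, unique, unknown or untested is made for them only; others in the source may bear on it.

Of the compounds shown here, two have been measured in a functional assay for agonist activity at P2Y purinoceptor 2 (Homo sapiens), read by FLIPR (a higher number here means that more compound is needed for the effect, a lower number that less compound is needed), so far. Compound 1 `O=P(O)(O)OP(=O)(O)OP(=O)(O)OC[C@H]1O[C@@H](c2nc3cc(C(F)(F)F)ccc3s2)[C@H](O)[C@@H]1O` gives 10 nM in this assay, and compound 2 `COc1ccc2nc([C@@H]3O[C@H](COP(=O)(O)OP(=O)(O)OP(=O)(O)O)[C@@H](O)[C@H]3O)sc2c1` gives 42 nM. Compound 2 thus stands at the higher of the two numbers; the difference to compound 1 is beyond the scatter, so more of compound 2 is needed for the same effect. Compound 3 `O=P(O)(O)OP(=O)(O)OP(=O)(O)OC[C@H]1O[C@@H](c2nc3ccccc3s2)[C@H](O)[C@@H]1O` keeps the whole core of compound 2 and differs only in one place: hydrogen in place of methoxy on an aromatic carbon. Among the measured compounds shown here, no pair of measured compounds shows what this particular change does, so the expectation rests on the size of the group removed, which is small. The step from compound 2 to compound 3 is expected to be a 1.4-fold lower number from compound 2 to compound 3 (0.15 log units; within the scatter), a shift that may not exceed the scatter. Compound 3 is therefore expected to give about 30 nM in this assay, within a range from 8 nM to 110 nM.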

Compound 3, half-maximal effective concentration: 22 nM
Compound 3: the middle estimate sits 1.4-fold (0.13 log units) above what was measured; the range from low to high includes it.
By their numbers in this assay, from the lowest: compound 1; then compounds 3 and 2 (each within the scatter of the next).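

In this assay, among the compounds shown here, compound 3 gives the first single-change readings for this series. Removing the methoxy gives a 1.9-fold lower number from compound 2 to compound 3 (0.28 log units; within the scatter), so on this aromatic carbon the group can be lost without a change that stands clear of the scatter. Replacing trifluoromethyl with hydrogen, by contrast, gives a 2.2-fold higher number from compound 1 to compound 3 (0.34 log units; beyond the scatter), a modest loss that goes beyond the scatter and shows that the trifluoromethyl of compound 1 counts for more in this assay than the methoxy of compound 2. Nothing measured here gives a reason for either step.

Still open, going by these compounds, is whether a fluorine, a chlorine or an amine in place of the methoxy would also stay within the scatter of compound 3. These three compounds also cannot show how a methoxy would behave on the aromatic carbon that carries trifluoromethyl in compound 1.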